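A few compounds are considered here, and "the series" means these few. Any claim that something is new, unique, unknown or untested is made for them only; others in the source may bear on it.

The compounds here share one core, carrying a chain that ends in a free amine and a six-membered ring with two nitrogens that bears the group under study. Compound 1 `NCCNc1cc(N2CCN(C(=O)CCc3ccccc3)CC2)nc2ccccc12` is one of them. In an ADME assay on HEp-2 cells (Homo sapiens) for cytotoxicity, read by CCK-8 assay, with a stated time of 6 days (on this read-out lower numbers stand for higher toxicity in this test and higher numbers for lower toxicity in this test), compound 1 gives > 100000 nM, which is a limit of the assay rather than a number. Compound 2 `NCCNc1cc(N2CCN(C(=O)C3(c4ccccc4)CCCC3)CC2)nc2ccccc12` carries a 1-phenylcyclopentyl instead of the phenethyl on the carbonyl carbon, and in this assay compound 2 gives > 100000 nM, again a limit. Compound 3 `NCCNc1cc(N2CCN(C(=O)C3(c4ccccc4)CCC3)CC2)nc2ccccc12` carries a 1-phenylcyclobutyl there, and in this assay compound 3 gives > 100000 nM, also a limit. The steps a step that the two limits leave unreadable from compound 1 to compound 2, a step that the two limits leave unreadable from compound 1 to compound 3 and a step that the two limits leave unreadable from compound 2 to compound 3 therefore carry no readable size; all that the numbers show is the limit of > 100000 nM in this assay, at which 3 of the 3 values shown sit.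

Compound 4 `NCCNc1cc(N2CCN(c3ccccc3Cl)CC2)nc2ccccc12` has not yet been measured. It differs from compound 1 by 2-chlorophenyl in place of phenethylcarbonyl on an amine nitrogen in a ring. Among the measured compounds shown here, no measured step touches this position, and every measured step is unreadable, so neither size nor direction can be taken from them for this assay. The step expected in this assay is a number no higher from compound 1 to compound 4 (the limit leaves the size open). Compound 4 is estimated at 100000 nM, with a range from 20000 nM to 300000 nM.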

Compound 4, half-maximal cytotoxic concentration: 20800 nM
Compound 4: the middle estimate sits 4.8-fold (0.68 log units) above what was measured; the range from low to high includes it.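

In this assay, among the compounds shown here, this ring nitrogen is a place where a change can be read, which the earlier compounds could not show: putting 2-chlorophenyl in place of phenethylcarbonyl gives an at least 4.8-fold lower number from compound 1 to compound 4 (0.68 log units; beyond the scatter). On this read-out a lower number stands for higher toxicity in the test, so this change moves the series towards toxicity, while the swaps among phenethyl, 1-phenylcyclopentyl and 1-phenylcyclobutyl on the carbonyl carbon cannot be read at all. Compound 4 is the only compound here with a true number, and the values of the other three are limits: the limit of > 100000 nM in this assay, at which 3 of the 4 values shown sit.

The change to compound 4 alters several things at once, removing the carbonyl and the chain and bringing in a chlorine on an aromatic ring attached directly to the nitrogen, so the compounds shown do not tell which of these accounts for the step. A plain phenyl on this nitrogen would isolate the part played by the chlorine, and a benzoyl would show what happens when the carbonyl stays but the chain goes.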